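Amide placement on the phenyl ring of the piperidine series

This account rests on a few compounds, and the source may have more. Where it says the series, first, only, none or still open, it means among the compounds named here.

Compound 3 `CC(=O)Nc1ccccc1C1CCN(CCCn2c(-c3ccc(Cl)cc3)nc3ccccc32)CC1` sits at a limit in an assay for displacement of a labelled ligand from melanin-concentrating hormone receptor 1 (Homo sapiens), read by fluorescence; on this read-out higher numbers stand for weaker inhibition and lower numbers for stronger inhibition: the value > 6000 nM is the assay's limit and not a number, so compound 3 stands outside the measured range of the series (the limit of > 6000 nM in this assay, at which 1 of the 3 values shown sits). Compound 1 `CC(=O)Nc1cccc(C2CCN(CCCn3c(-c4ccc(C#N)cc4)nc4ccccc43)CC2)c1` gives 16 nM in this assay, and compound 2 `CC(=O)Nc1cccc(C2CCN(CCCn3c(-c4ccc(Cl)cc4Cl)nc4ccccc43)CC2)c1` gives 3 nM; the change from compound 1 to compound 2 is a 5.3-fold lower number from compound 1 to compound 2 (0.73 log units; beyond the scatter). Compound 4 `CC(C)C(=O)Nc1cccc(C2CCN(CCCn3c(-c4ccc(Cl)cc4)nc4ccccc43)CC2)c1` differs from compound 3 in that (3-((isopropylcarbonyl)amino)phenyl in place of 2-acetamidophenyl on a saturated ring carbon). Within the data shown here, no measured step covers this exact change; the only measured step varies the aryl group on the core, not the amide-bearing phenyl. Compound 1 and compound 2, whose amide-bearing phenyl is arranged as in compound 4, both give measured numbers well inside the range, whereas compound 3 does not. Compound 4 is therefore expected to return into the measured range, with a step of an at least 600-fold lower number from compound 3 to compound 4 (2.77 log units; beyond the scatter) estimated to be large and downward. For compound 4 the estimate in this assay is 10 nM, within 2 nM to 60 nM.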

Compound 4, half-maximal inhibitory concentration: 5 nM
Beside the measured number, compound 4's estimate is 2.0-fold (0.30 log units) above it, within the range that was stated.
By their numbers in this assay, from the lowest: compounds 2 and 4 (each within the scatter of the next); then compound 1. At a limit, above all of these: compound 3.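

In this assay, among these compounds, replacing 2-acetamidophenyl with 3-((isopropylcarbonyl)amino)phenyl on the saturated ring carbon gives the only measured step at this position, and it is large: an at least 1200-fold lower number from compound 3 to compound 4 (3.07 log units; beyond the scatter). That step has a floor and no fixed size, since compound 3 sits at a limit and not at a number: the limit of > 6000 nM in this assay, at which 1 of the 4 values shown sits. The earlier step varied only the aryl group on the core, whereas this one shows that the group on the saturated ring carbon can decide whether a compound falls inside the measured range at all.

The compounds shown do not separate the place of the amide on the phenyl ring from the change in its acyl part, as the two differ together in this step. Going by these compounds, how a free amine or a carboxylic acid in place of the amide would read in this assay also remains open.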